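A few compounds are considered here, and "the series" means these few. Any claim that something is new, unique, unknown or untested is made for them only; others in the source may bear on it.

Measured compounds in a functional assay on MCF7 cells (Homo sapiens) for antiproliferative activity, read by MTT assay, with a stated time of 72 h; a higher number here means a weaker inhibitor, a lower number a stronger inhibitor:
compound 1 `CCN1CCN(c2cc(C)c3cc(NC(=O)c4cccnc4)ccc3n2)CC1` — 26600 nM
compound 2 `CNc1cc(C)c2cc(NC(=O)c3ccc(Cl)c(Cl)c3)ccc2n1` — 2520 nM
compound 3 `Cc1cc(N2CCCC2)nc2ccc(NC(=O)c3ccc(Cl)c(Cl)c3)cc12` — 26300 nM

Compound 1 gives the highest of the three numbers in this assay; its number and that of compound 3 lie within the scatter of each other, while compound 2 sits well below both. Within the data shown here, the one step in this assay, a 10-fold higher number from compound 2 to compound 3 (1.02 log units; beyond the scatter), concerns the amine on the core and not the amide aryl group, so no measured step bears on the change that leads to compound 4 `CCN1CCN(c2cc(C)c3cc(NC(=O)c4ccc(C)cc4)ccc3n2)CC1`: 4-methylphenyl in place of pyridin-3-yl on a carbonyl carbon. Compounds 2 and 3 carry a different aryl group from compound 1, and differ from it in the amine as well, so their values only show that the aryl group can matter. Without a direct precedent, no step beyond the scatter is expected from compound 1 to compound 4, a 1.7-fold lower number from compound 1 to compound 4 (0.22 log units; within the scatter). Compound 4 is thus estimated at 16000 nM in this assay, with a range from 4000 nM to 60000 nM.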

Compound 4, half-maximal inhibitory concentration: 6740 nM
Compound 4: the middle estimate sits 2.4-fold (0.38 log units) above what was measured, within the range that was stated.
By their numbers in this assay, from the lowest: compound 2; then compound 4; then compounds 3 and 1 (each within the scatter of the next).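

With the amine on the core held constant, the group on the carbonyl carbon matters by itself in this assay: 4-methylphenyl in place of pyridin-3-yl gives a 3.9-fold lower number from compound 1 to compound 4 (0.60 log units; beyond the scatter). Among these compounds, the earlier step covered only the amine, so this is the first direct reading at this position. Nothing at hand accounts for the step.

The change removes the ring nitrogen and adds the methyl together, so the two remain unseparated. From the compounds shown here alone, an unsubstituted phenyl on the same carbonyl carbon would separate them, and whether the step carries over to compounds bearing methylamino remains open.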